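Lengthening the Chain from Compound 2 to Compound 3

The source may hold more compounds than are shown below. What is called first, only, known or untested is meant among the compounds shown, and "the series" means these compounds.

Compound 1 `COc1cc(N)c(Cl)cc1C(=O)NC1CCN(CCCCCO)CC1` and compound 2 `COc1cc(N)c(Cl)cc1C(=O)NC1CCN(CCN2CCCCC2)CC1` share one core and differ only in the group on the chain that leaves the ring nitrogen. In a functional assay on HEK293 cells for activation of 5-hydroxytryptamine receptor 4 (Homo sapiens), read by cAMP accumulation (on this read-out lower numbers stand for smaller maximal responses and higher numbers for larger maximal responses), compound 1 reaches > 100%, which is a limit of the assay rather than a number. In this assay compound 2 reaches > 100%, again a limit. The step that the two limits leave unreadable from compound 1 to compound 2 therefore cannot be read, because of the limit of > 100% in this assay, at which 2 of the 2 values shown sit.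

Compound 3 `COc1cc(N)c(Cl)cc1C(=O)NC1CCN(CCCCCN2CCCCC2)CC1` has not yet been measured. It differs from compound 2 by 3-(piperidin-1-yl)propyl in place of piperidin-1-yl on a saturated chain carbon, two bonds along the chain from an amine nitrogen in a ring. Going by the values given here, no measured step bears on this change, and the only step known gives no size, so nothing points to a change in this assay beyond the scatter. Compound 3 is expected to stay near the limit, with the step of a number no higher from compound 2 to compound 3 (the limit leaves the size open) estimated as none beyond the scatter. Compound 3 is estimated at 100%, between 85% and 115%.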

Compound 3, intrinsic activity: the largest response reached, in percent of the reference agonist's: > 100%
Compound 3: only a limit was reported (the forecaster's own chance of this, stated with the estimate: 65%); the middle value sits exactly at the limit.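

Going by these compounds alone, no step between compound 1, compound 2 and compound 3 can be read, because all three values are limits rather than numbers: the limit of > 100% in this assay, at which 3 of the 3 values shown sit. The compounds shown leave open the actual size of each maximal response, and so whether 3-(piperidin-1-yl)propyl in place of piperidin-1-yl changes it at all.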